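Removing the ethoxycarbonyl group from compound 1

The source may hold more compounds than are shown below. What is called first, only, known or untested is meant among the compounds shown, and "the series" means these compounds.

Compound 1 `CCOC(=O)c1cc(-c2cc(OC)c(OC)c(OC)c2)c(-c2ccc(OC)cc2)s1` is the starting point of this account. In a functional assay on HT-1080 cells (Homo sapiens) for antiproliferative activity, read by MTT assay, with a stated time of 72 h (a lower number here means a stronger inhibitor, a higher number a weaker inhibitor), compound 1 gives 8370 nM, the highest of the two numbers recorded. Its nearest neighbour is compound 3 `CCOC(=O)c1cc(-c2cc(OC)c(OC)c(OC)c2)c(-c2ccc3ccccc3c2)s1`, which in this assay gives 1150 nM, a change of a 7.3-fold lower number from compound 1 to compound 3 (0.86 log units; beyond the scatter). Compound 2 `CCOC(=O)c1cc(-c2cc(OC)c(OC)c(OC)c2)c(-c2cccc(Br)c2)s1` in this assay reaches only the limit of > 100000 nM, a limit and not a number (the limit of > 100000 nM in this assay, at which 1 of the 3 values shown sits). The change an at least 11-fold higher number from compound 1 to compound 2 (1.07 log units; beyond the scatter) is therefore an extent rather than a measured step. Compound 4 `COc1ccc(-c2sccc2-c2cc(OC)c(OC)c(OC)c2)cc1` differs from compound 1 by hydrogen in place of ethoxycarbonyl on an aromatic carbon. For the measured compounds named here, none of the measured steps touches this group: every one of them exchanges the aryl group on the other ring carbon, so no measured step bears directly on the present change. Compound 4 is therefore expected to give roughly 15000 nM, within 4000 nM to 60000 nM. The expected step is a 1.8-fold higher number from compound 1 to compound 4 (0.25 log units; within the scatter), with little confidence in its direction.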

Compound 4, half-maximal inhibitory concentration: 4590 nM
The estimate for compound 4 lay 3.3-fold (0.51 log units) above the measured number; the range from low to high includes it.
By their numbers in this assay, from the lowest: compound 3; then compounds 4 and 1 (each within the scatter of the next). At a limit, above all of these: compound 2.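

Replacing ethoxycarbonyl with hydrogen, on the aromatic carbon next to the ring sulfur, gives a 1.8-fold lower number from compound 1 to compound 4 (0.26 log units; within the scatter) in this assay and so leaves the two compounds indistinguishable in this assay. For the compounds shown here, this is the first look at this position, and the whole ethoxycarbonyl group can go without a change beyond the scatter, whereas the earlier steps, all at the aryl group on the other ring carbon, lay beyond it. Nothing shown here offers an explanation for this outcome.

On these data alone, whether a carboxylic acid or a primary amide on this carbon would match ethoxycarbonyl and hydrogen remains open. So does whether hydrogen would be tolerated equally alongside the naphthalen-2-yl group of compound 3, since the exchange is shown only alongside the 4-methoxyphenyl group.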